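A few compounds are considered here, and "the series" means these few. Any claim that something is new, unique, unknown or untested is made for them only; others in the source may bear on it.

Three compounds share a core in which a pyrazole-bearing chain ends in a carbonyl carbon carrying an aromatic ring, and all three were tested in a functional assay on NCI-H522 cells (Homo sapiens) for inhibition, read by sulforhodamine B assay, with a stated time of 48 h; a lower number here means a stronger inhibitor of growth, a higher number a weaker inhibitor of growth. Compound 1 `COc1ccc(-c2cc(/C=C/C(=O)c3ccc(N)cc3)[nH]n2)cc1` gives 1210 nM in this assay. Compound 2 `COc1cc(-c2cc(/C=C/C(=O)c3ccc(N)cc3)[nH]n2)cc(OC)c1OC` gives 1620 nM in this assay. Compound 3 `COc1cc(-c2cc(/C=C/C(=O)c3ccc(Cl)c(Cl)c3)[nH]n2)cc(OC)c1OC` gives 1330 nM in this assay. Among these three numbers compound 2 stands highest, but its separation from the others is small: the nearest is compound 3 and the furthest is compound 1, and both gaps lie within the scatter of repeated measurements, so no order can be read from them.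

Compound 4 `COc1cc(-c2cc(/C=C/C(=O)c3ccc(F)c(F)c3)[nH]n2)cc(OC)c1OC` has not yet been measured. Relative to compound 2 it carries 3,4-difluorophenyl in place of 4-aminophenyl on a carbonyl carbon. Among the compounds with values here, the one measured step that bears on this change is the move to a 3,4-dichlorophenyl on the same carbonyl carbon. Because a 1.2-fold lower number from compound 2 to compound 3 (0.09 log units; within the scatter) left the number essentially where it was, the 3,4-difluorophenyl ring is expected to do the same, with no step beyond the scatter. The expected change is a 1.1-fold lower number from compound 2 to compound 4 (0.03 log units; within the scatter). Compound 4 is therefore estimated at 1500 nM in this assay, within a range from 700 nM to 3500 nM.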

Compound 4, concentration for 50% growth inhibition: 1570 nM
Estimate against measurement, compound 4: 1.0-fold (0.02 log units) below; low and high end bracket the measured number.
By their numbers in this assay, from the lowest: compounds 1, 3, 4 and 2 (each within the scatter of the next).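

In this assay, replacing the 4-aminophenyl on the carbonyl carbon with 3,4-difluorophenyl gives a 1.0-fold lower number from compound 2 to compound 4 (0.01 log units; within the scatter), and exchanging the two halogen-bearing rings gives a 1.2-fold higher number from compound 3 to compound 4 (0.07 log units; within the scatter). With this second halogen-bearing ring, all three rings tested at this position on the shared core lie within the scatter of one another, even though the 4-aminophenyl carries a hydrogen-bond donor and acceptor and the 3,4-difluorophenyl carries neither. No measurement here explains why these ring changes leave the number in place.

From the compounds shown here alone, all the groups compared at this position are substituted phenyl rings, so it remains open whether a ring bearing a carboxylic acid, or a saturated cyclohexyl ring, would produce a step beyond the scatter. Going by these compounds, it is also open whether the 3,4-difluorophenyl would behave the same way on the core of compound 1.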